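The source may hold more compounds than are shown below. What is called first, only, known or untested is meant among the compounds shown, and "the series" means these compounds.

Compound 1 `CC(C)CNc1nc(N)nc2c1ncn2/C=C1/CC1(CO)CO` stands in an ADME assay on CCRF-HSB-2 cells (Homo sapiens) for cytotoxicity, with a stated time of 7 days (a lower number here means that less compound is tolerated, a higher number that more compound is tolerated), only as a limit of the assay: compound 1 gives > 20000 nM. The two neighbours that differ from it in one place are reported the same way. Compound 2 `CCCCNc1nc(N)nc2c1ncn2/C=C1/CC1(CO)CO` gives in this assay > 20000 nM, a limit. Compound 3 `Nc1nc(N2CCCC2)c2ncn(/C=C3/CC3(CO)CO)c2n1` gives in this assay > 20000 nM, likewise a limit. The steps a step that the two limits leave unreadable from compound 1 to compound 2 and a step that the two limits leave unreadable from compound 1 to compound 3 therefore carry no readable size, and the step that the two limits leave unreadable from compound 2 to compound 3 is in the same position, because of the limit of > 20000 nM in this assay, at which 3 of the 3 values shown sit.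

Compound 4 `Nc1nc(SC2CCCC2)c2ncn(/C=C3/CC3(CO)CO)c2n1` has not yet been measured in this assay. It departs from compound 1 by cyclopentylsulfanyl in place of isobutylamino on an aromatic carbon. For the measured compounds named here, of the measured steps, those from compound 1 to compound 3 and from compound 2 to compound 3 also replace isobutylamino or butylamino with a five-membered ring on the same aromatic carbon, yet both are unreadable, and no measured step covers the exchange of an amino nitrogen for sulfur. None of the three values points away from the limit, so compound 4 is expected to sit there as well. The expected step is estimated as a step that the limit leaves unreadable from compound 1 to compound 4. The estimate for compound 4 is 30000 nM, in the range from 12000 nM to 100000 nM.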

Compound 4, half-maximal cytotoxic concentration: 91000 nM
Estimate against measurement, compound 4: 3.0-fold (0.48 log units) below; the measured number falls inside the stated range.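

The steps from compound 1, compound 2 and compound 3 to compound 4 in this assay cannot be read, because compound 1, compound 2 and compound 3 are reported only as limits: the limit of > 20000 nM in this assay, at which 3 of the 4 values shown sit.

Open, as far as these compounds go, is whether cyclopentylsulfanyl differs from isobutylamino, butylamino or pyrrolidin-1-yl on that aromatic carbon, and how compound 1, compound 2 and compound 3 rank among themselves.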